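Swapping 4-bromophenyl for furan-2-yl on compound 3

The compounds below may be only part of what the source reports. "The series", "measured", "known", "first", "only" and "open" are said of these compounds alone.

Compound 1 (`CC(=O)O[C@@H]1C[C@@H](OC(=O)c2ccccc2)/C(C)=C/[C@H]2[C@@H](OC(=O)c3ccccc3)[C@@H](C)[C@H](O)[C@]2(OC(C)=O)[C@H](O)[C@](C)(O)/C=C/C1(C)C`) gives > 150000 nM as a limit, not a number
Compound 2 (`CC(=O)O[C@@H]1C[C@@H](OC(=O)c2ccccc2)/C(C)=C/[C@H]2[C@@H](OC(=O)c3ccccc3)[C@@H](C)[C@H](OS(=O)(=O)c3ccc(C)cc3)[C@]2(OC(C)=O)[C@H](O)[C@](C)(O)/C=C/C1(C)C`) gives > 150000 nM as a limit, not a number
Compound 3 (`CC(=O)O[C@@H]1C[C@@H](OC(=O)c2ccccc2)/C(C)=C/[C@H]2[C@@H](OC(=O)c3ccccc3)[C@@H](C)[C@H](OC(=O)c3ccc(Br)cc3)[C@]2(OC(C)=O)[C@H](O)[C@](C)(O)/C=C/C1(C)C`) gives 81300 nM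

All three compounds were tested in a functional assay on HepG2 cells (Homo sapiens) for inhibition, read by MTT assay, with a stated time of 48 h (on this read-out higher numbers stand for weaker inhibition and lower numbers for stronger inhibition), and share one core. For the measured compounds named here, compound 3 gives 81300 nM as the only true number in this set. Compound 1 and compound 2 share the limit of > 150000 nM in this assay, at which 2 of the 3 values shown sit, and so offer no exact number for comparison.

Compound 4 (`CC(=O)O[C@@H]1C[C@@H](OC(=O)c2ccccc2)/C(C)=C/[C@H]2[C@@H](OC(=O)c3ccccc3)[C@@H](C)[C@H](OC(=O)c3ccco3)[C@]2(OC(C)=O)[C@H](O)[C@](C)(O)/C=C/C1(C)C`) keeps the core and changes one group, counted as furan-2-yl in place of 4-bromophenyl on a carbonyl carbon in full: furan-2-yl in place of 4-bromophenyl on a carbonyl carbon.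

Going by the values given here, two measured steps bear on this change, and both bring in the (4-bromophenyl)carbonyl group that compound 4 gives up. They are an at least 1.8-fold lower number from compound 1 to compound 3 (0.26 log units; that floor lies within the scatter) and an at least 1.8-fold lower number from compound 2 to compound 3 (0.26 log units; that floor lies within the scatter) as measured. Each is only a floor within the scatter, so the group has not been shown to matter, and no measured compound carries furan-2-yl. The expected step is therefore a 1.2-fold higher number from compound 3 to compound 4 (0.09 log units; within the scatter) and stays within the scatter, leaning slightly towards a higher number. A limit instead of a number is also possible for compound 4. For compound 4 the estimate is 100000 nM with an expected range from 50000 nM to 180000 nM as the likely span of results.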

Compound 4, half-maximal inhibitory concentration: > 150000 nM
Compound 4: no number, only a limit; the forecaster's own chance of this, stated with the estimate: 45%; at least 1.5-fold (0.17 log units) between middle value and limit.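

In this assay the exchange of 4-bromophenyl for furan-2-yl on this carbonyl carbon gives an at least 1.8-fold higher number from compound 3 to compound 4 (0.26 log units; that floor lies within the scatter) and so adds a second aromatic group to the comparison at this oxygen, although the size of that step is only a floor and remains within the scatter. An ester at this oxygen therefore does not by itself bring a compound to a true number, since compound 4 carries one and still gives only a limit, but the data cannot show that the 4-bromophenyl group really matters. The steps from compound 1 and compound 2 to compound 4 cannot be read, with a limit at both ends, and the set now gathers at a single ceiling: the limit of > 150000 nM in this assay, at which 3 of the 4 values shown sit.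

For the compounds shown here, compound 3 remains the only true number here, so it is still open whether the bromine, the six-membered ring or neither accounts for it. A plain phenyl group on the same carbonyl carbon could help to separate bromine from ring, while an amine or a carboxylic acid on that group would test a very different kind of substituent at this position.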